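N-substituent changes on the piperidine amine of the benzamide series

The source may hold more compounds than are shown below. What is called first, only, known or untested is meant among the compounds shown, and "the series" means these compounds.

Measured compounds and values in an assay on cells for inhibition of sodium- and chloride-dependent glycine transporter 1 (Homo sapiens); on this read-out lower numbers stand for an effect already at smaller amounts and higher numbers for an effect only at larger amounts of compound:
- compound 1 `COc1cc(C(F)(F)F)cc(C(F)(F)F)c1C(=O)NC1(c2ccccc2)CCCN(C2CCCC2)C1`: 270 nM
- compound 2 `COc1cc(C(F)(F)F)cc(C(F)(F)F)c1C(=O)NC1(c2ccccc2)CCCN(CC2CC2)C1`: 380 nM
- compound 3 `COc1cc(C(F)(F)F)cc(C(F)(F)F)c1C(=O)NC1(c2ccccc2)CCCN(Cc2ccccc2)C1`: 6700 nM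

Compound 3 gives the highest number of the three; the nearest is compound 2 and the furthest is compound 1. The two steps onto compound 3 both sit at the same position of the shared core: a 25-fold higher number from compound 1 to compound 3 (1.39 log units; beyond the scatter) and an 18-fold higher number from compound 2 to compound 3 (1.25 log units; beyond the scatter), while a 1.4-fold higher number from compound 1 to compound 2 (0.15 log units; within the scatter).

Compound 4 `COc1cc(C(F)(F)F)cc(C(F)(F)F)c1C(=O)NC1(c2ccccc2)CCCN(C(C)=O)C1` differs from compound 3 as follows: acetyl in place of benzyl on an amine nitrogen in a ring. For the measured compounds named here, no measured step introduces an acetyl group at this nitrogen, so the expectation rests only on the observation that both measured replacements of benzyl by a non-aromatic group at this position gave large steps toward lower numbers. An acetyl group is not an alkyl group, so the expected step is smaller and carries wide uncertainty. A lower number than for compound 3 is expected, with an estimated step of a 5.6-fold lower number from compound 3 to compound 4 (0.75 log units; beyond the scatter). Compound 4 is therefore estimated at 1200 nM in this assay, with a range from 150 nM to 9000 nM.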

Compound 4, half-maximal effective concentration: > 10000 nM
Compound 4: no number, only a limit; the forecaster's own chance of this, stated with the estimate: 5%; middle value at least 8.3-fold (0.92 log units) from the limit.
By their numbers in this assay, from the lowest: compounds 1 and 2 (each within the scatter of the next); then compound 3. At a limit, above all of these: compound 4.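

In this assay, compound 4 gives a limit and not a number: the limit of > 10000 nM in this assay, at which 1 of the 4 values shown sits.

Even so, acetyl at this ring nitrogen gives large steps against the two non-aromatic alkyl groups, an at least 26-fold higher number from compound 2 to compound 4 (1.42 log units; beyond the scatter) and an at least 37-fold higher number from compound 1 to compound 4 (1.56 log units; beyond the scatter), so compound 4 goes against any reading that replacing benzyl with a non-aromatic group lowers the number. Against benzyl only a floor can be read, an at least 1.4-fold higher number from compound 3 to compound 4 (0.17 log units; that floor lies within the scatter), which leaves unsettled whether acetyl and benzyl differ beyond the scatter.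

From the compounds shown here alone, how far the true value of compound 4 lies past its limit stays open. So does whether an ethyl group or a methylsulfonyl group on this nitrogen would give numbers close to those of compound 1 and compound 2 or follow compound 4.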